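A few compounds are considered here, and "the series" means these few. Any claim that something is new, unique, unknown or untested is made for them only; others in the source may bear on it.

Working notes on the series. Among the measured compounds shown here, compound 1 `C#CCNC(=O)/C(C)=C(\C)c1ccc(Cl)cc1` in a toxicity assay on the whole organism (strain Icem-CET (SPF Caw)) for cytotoxicity, with Mus musculus as the target (on this read-out lower numbers stand for an effect already at smaller amounts and higher numbers for an effect only at larger amounts of compound), gives 200 mg/kg, the highest of the three numbers measured so far, though neither of the other two is separated from it by more than the scatter. Compound 2 `C#CCNC(=O)/C(C)=C(\C)c1cc(OC)c(OC)c(OC)c1` gives 150 mg/kg in this assay, the nearest number to compound 1. For the measured compounds named here, compound 3 `C/C(C(=O)NC1CC1)=C(/C)c1ccc(Cl)cc1` gives 150 mg/kg in this assay, and the only single-point step measured, a 1.3-fold lower number from compound 1 to compound 3 (0.12 log units; within the scatter), changes the substituent on the amide nitrogen and stays within the scatter.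

Compound 4 `C#CCNC(=O)/C(C)=C(\C)c1ccc(F)cc1` has not yet been measured in this assay. It differs from compound 1 as follows: fluoro in place of chloro on an aromatic carbon. Going by the values given here, no measured step touches the substituent on the aromatic ring; the one measured step, from compound 1 to compound 3, concerns the amide nitrogen and was flat. The series therefore gives no ground to expect a change beyond the scatter for the halogen swap, and the expectation is that compound 4 falls close to compound 1, the estimated step from compound 1 to compound 4 being no change at the digits printed from compound 1 to compound 4 (within the scatter). For compound 4 in this assay the estimated value is 200 mg/kg, with an expected range from 100 mg/kg to 400 mg/kg.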

Compound 4, dose for half-maximal effect: 100 mg/kg
The estimate for compound 4 lay 2.0-fold (0.30 log units) above the measured number, and the stated range covers the measured number.
By their numbers in this assay, from the lowest: compounds 4, 2, 3 and 1 (each within the scatter of the next).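

Fluoro in place of chloro on an aromatic carbon, para to a large group, gives the first measured step at this ring position in this assay: a 2.0-fold lower number from compound 1 to compound 4 (0.30 log units; within the scatter). Like the change on the amide nitrogen (a 1.3-fold lower number from compound 1 to compound 3 (0.12 log units; within the scatter)), this swap of one halogen for another stays within the scatter, so this read-out does not separate chloro from fluoro at this position, although the single pair offers no basis for a wider claim about halogens or other ring substituents. Nothing measured alongside these numbers bears on the result, and the data offer no explanation for it.

Going by these compounds, it remains open whether a group of a different kind on this aromatic carbon, such as an amine, a carboxylic acid or trifluoromethyl, would move the number beyond the scatter or leave it as flat as the halogen swap did. Also open, on these data alone, is whether fluoro on the ring and cyclopropyl on the amide nitrogen, taken together in one compound, would still stay within the scatter of compound 1.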